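The source may hold more compounds than are shown below. What is called first, only, known or untested is meant among the compounds shown, and "the series" means these compounds.

Measured so far in this study:

Compound 1, `CC(O)(CSc1ccc(S(F)(F)(F)(F)F)cc1)C(=O)Nc1ccc(S(F)(F)(F)(F)F)cc1`: 24400 nM
Compound 2, `CC(O)(CSc1ccc(F)cc1)C(=O)Nc1ccc(S(F)(F)(F)(F)F)cc1`: 13500 nM
Compound 3, `CC(O)(CSc1ccc(S(F)(F)(F)(F)F)cc1)C(=O)Nc1cccc(S(F)(F)(F)(F)F)c1`: 13100 nM

The three were tested in a functional assay on CWR22R cells (Homo sapiens) for antiproliferative activity, read by propidium iodide staining, with a stated time of 96 h; on this read-out higher numbers stand for weaker inhibition and lower numbers for stronger inhibition. Compound 1 and compound 2 share a core and differ by one fluorine atom in place of a group of 6 heavy atoms (5 fluorine, 1 sulfur; no ring), on an aromatic carbon. That change produced a 1.8-fold lower number from compound 1 to compound 2 (0.26 log units; within the scatter), so it did not move the read-out beyond what repeated measurements of this kind usually show. Compound 3 is built from the same atoms as compound 1, joined differently; the difference between the two cores is not broken down here. In this assay compound 3 stands within the scatter of both compound 2 and compound 1, so no order among the three is claimed.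

Compound 4, `CC(O)(CSc1ccc(F)cc1)C(=O)Nc1cccc(S(F)(F)(F)(F)F)c1`, has not yet been measured. It relates to compound 3 by one fluorine atom in place of a group of 6 heavy atoms (5 fluorine, 1 sulfur; no ring), on an aromatic carbon, which is the same change as that from compound 1 to compound 2, made here on the core of compound 3.

Because the earlier instance gave a 1.8-fold lower number from compound 1 to compound 2 (0.26 log units; within the scatter), compound 4 is expected to show a step of about a 1.5-fold lower number from compound 3 to compound 4 (0.16 log units; within the scatter). On that basis compound 4 is estimated at 9000 nM in this assay. The expected range for compound 4 runs from 4000 nM to 25000 nM, allowing for the possibility that the same change on a different core does not repeat the earlier step.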

Compound 4, half-maximal inhibitory concentration: 30200 nM
Estimate against measurement, compound 4: 3.4-fold (0.53 log units) below; measured number outside the range, above it.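

In this assay, putting fluoro in place of the group of 6 heavy atoms (5 fluorine, 1 sulfur) on the core of compound 3 gave a 2.3-fold higher number from compound 3 to compound 4 (0.36 log units; beyond the scatter), a modest step in the direction opposite to the one the estimate had taken from the earlier instance. Set beside that instance, the same change does not give the same result on the two cores: the same change on two cores in this assay, a 1.8-fold lower number (0.26 log units; within the scatter) from compound 1 to compound 2 and a 2.3-fold higher number (0.36 log units; beyond the scatter) from compound 3 to compound 4, 4.2-fold (0.62 log units) apart, beyond the scatter of two such steps. Going by these compounds alone, this shows that the change cannot be carried from one core to the other as a fixed step, yet it rests on only two cores and one of the two steps lies within the scatter, so it shows neither a reversal that would hold on further cores nor what underlies the gap.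

Going by these compounds, all four compounds carry either fluoro or the group of 6 heavy atoms on the ring attached through sulfur, so it remains open how a trifluoromethyl or a nitrile in that place would compare on either core. On these data alone, it also remains open whether the step would hold on a third core, for instance one with an amine in place of the hydroxyl.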